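The compounds below may be only part of what the source reports. "The series", "measured", "known", "first", "only" and "open" are said of these compounds alone.

Compound 1, `C=C(C)[C@@H]1CC=C(Cn2cc(COc3cc(C4NC(=O)NC(C)=C4C(=O)OCC)ccc3OC)nn2)CC1`, gives > 100000 nM in a functional assay on 786-0 cells (Homo sapiens) for inhibition, read by sulforhodamine B assay, with a stated time of 48 h; a higher number here means a weaker inhibitor of growth, a lower number a stronger inhibitor of growth; this is a limit of the assay, not a number.
Compound 2, `C=C(C)[C@@H]1CC=C(Cn2cc(COc3cccc(C4NC(=O)NC(C)=C4C(C)=O)c3)nn2)CC1`, gives 44100 nM in this assay.

For the measured compounds named here, compound 2 is the only compound with a numeric value. Compound 1, which also carries a methoxy, sits at the limit of > 100000 nM in this assay, at which 1 of the 2 values shown sits, a limit. Compound 3, `C=C(C)[C@@H]1CC=C(Cn2cc(COc3cc(C4NC(=O)NC(C)=C4C(C)=O)ccc3OC)nn2)CC1`, is not yet measured; it differs from compound 2 by methoxy in place of hydrogen on an aromatic carbon. Going by the values given here, no measured pair isolates this change. A step toward weaker inhibition, or none beyond the scatter, is therefore expected. Compound 3 is estimated at 70000 nM, between 30000 nM and 160000 nM, which means an expected step of a 1.6-fold higher number from compound 2 to compound 3 (0.20 log units; within the scatter).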

Compound 3, concentration for total growth inhibition: > 100000 nM
Compound 3 ended at the assay's limit; the forecaster's own chance of this, stated with the estimate: 40%; middle value at least 1.4-fold (0.15 log units) away from the limit.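

Methoxy in place of hydrogen on this aromatic carbon weakens growth inhibition, with an at least 2.2-fold higher number from compound 2 to compound 3 (0.35 log units; beyond the scatter) in this assay. The step between compound 1 and compound 3 cannot be read, since both values are limits of the assay. Two of the compounds shown now share that limit: the limit of > 100000 nM in this assay, at which 2 of the 3 values shown sit.

The compounds shown leave open whether a hydroxyl or an amine on the same carbon would behave like methoxy. They also leave open whether methyl or ethoxy on the carbonyl carbon matters when methoxy is present.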